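Chloro to trifluoromethyl on the dichlorophenyl of compound 1

A few compounds are considered here, and "the series" means these few. Any claim that something is new, unique, unknown or untested is made for them only; others in the source may bear on it.

Two measured compounds share the core of compound 1 `O=C(Nc1ccc(-n2ccc3c(NC(=O)c4ccccc4)ncnc32)cc1)Nc1ccc(Cl)c(Cl)c1`. In a functional assay on A375P cells (Homo sapiens) for antiproliferative activity, read by MTT assay, with a stated time of 24 h (a higher number here means a weaker inhibitor, a lower number a stronger inhibitor), compound 1 gives 4000 nM, the lowest of the two numbers. Compound 2 `Nc1ncnc2c1ccn2-c1ccc(NC(=O)Nc2ccc(Cl)c(Cl)c2)cc1` in this assay gives 5400 nM. The step of a 1.4-fold higher number from compound 1 to compound 2 (0.13 log units; within the scatter), hydrogen in place of benzoyl on a nitrogen on an aromatic ring, stays within the scatter, so the two compounds are not distinguished.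

Compound 3 `O=C(Nc1ccc(-n2ccc3c(NC(=O)c4ccccc4)ncnc32)cc1)Nc1ccc(Cl)c(C(F)(F)F)c1` is not yet measured. It differs from compound 1 by trifluoromethyl in place of chloro on an aromatic carbon, read one bond further out as 3,4-dichlorophenyl to 4-chloro-3-(trifluoromethyl)phenyl. Going by the values given here, no measured step touches this ring; the only step in hand sits at the benzoyl and was within the scatter, so it bears only indirectly. No movement beyond the scatter is expected in this assay. Compound 3 is expected at 3000 nM, within a range from 1200 nM to 8000 nM. The expected step is a 1.3-fold lower number from compound 1 to compound 3 (0.12 log units; within the scatter).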

Compound 3, half-maximal inhibitory concentration: 4600 nM
Beside the measured number, compound 3's estimate is 1.5-fold (0.19 log units) below it; the measured number falls inside the stated range.
By their numbers in this assay, from the lowest: compounds 1, 3 and 2 (each within the scatter of the next).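

In this assay, going by these compounds alone, the first step on this ring, at the aromatic carbon ortho to a chloro group, is a 1.2-fold higher number from compound 1 to compound 3 (0.06 log units; within the scatter), so trifluoromethyl in place of chloro does not distinguish the two compounds. Together with the earlier step at the benzoyl, this means that neither of the two changes shown, one at each end of the shared core, separates its pair of compounds in this series. No measured evidence bears on this result.

From the compounds shown here alone, whether an amine, a hydroxyl group or a carboxylic acid at this aromatic carbon would give a step beyond the scatter remains open. Also open, going by these compounds, is whether trifluoromethyl at this position gives the same result with hydrogen in place of benzoyl, as in compound 2.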